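Dimethylamino in place of 2-methylpiperidinyl on the sulfonyl

A few compounds are considered here, and "the series" means these few. Any claim that something is new, unique, unknown or untested is made for them only; others in the source may bear on it.

The series shares a core carrying a chloro-substituted aryloxyacetic acid joined through an alkyne to a sulfonylated aryl ring. Compound 1 `CN(C)S(=O)(=O)c1ccc(F)c(C#Cc2cc(Cl)ccc2OCC(=O)O)c1` was measured in an ADME assay on a cell-free system (plasma, Rattus norvegicus) (a higher number here means a larger unbound share of the compound, a lower number a smaller unbound share), and gives 0.007. Among the compounds with values here, compound 2 `Cc1ccc(S(=O)(=O)N2CCCCC2C)cc1C#Cc1cc(Cl)ccc1OCC(=O)O` was also submitted, but in this assay compound 2 is recorded as "not determined" (no result reported), so it has no single number to stand on and no step between measured compounds can be drawn from it.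

Compound 3 `Cc1ccc(S(=O)(=O)N(C)C)cc1C#Cc1cc(Cl)ccc1OCC(=O)O` is the next compound to be measured. It differs from compound 2 in one place: dimethylamino in place of 2-methylpiperidin-1-yl on a sulfonyl sulfur. Within the data shown here, no measured step of this kind exists, so the size of the change in this assay cannot be read from a precedent; the account can only lean on compound 1, which carries the same dimethylsulfamoyl group and a closely related core.

Compound 3 is expected in this assay to show 0.008, within a range of 0.003 to 0.02, an estimate resting on compound 1, because compound 1 gives 0.007 in this assay.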

Compound 3, unbound fraction: 0.004
Compound 3: middle estimate off by 2.0-fold (0.30 log units), on the high side; the range from low to high includes it.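

With the dimethylsulfamoyl group held in place, methyl in place of fluoro on an aromatic carbon gives a step in this assay that stays within the usual scatter (a 1.8-fold lower number from compound 1 to compound 3 (0.24 log units; within the scatter)), so this swap on the shared core shows no readable difference in the unbound share. Compound 2 has no reported result, so the step to compound 3 at the sulfonyl sulfur cannot be read, and this measurement gives no size for the change from 2-methylpiperidin-1-yl to dimethylamino. Nothing measured here bears on why the values fall as they do.

The compounds shown therefore leave open whether the six-membered ring on the sulfonyl sulfur changes the unbound share at all, and whether another group there, such as morpholin-4-yl or a plain amino group, would move the number beyond the scatter. They also leave open how a methoxy group or a trifluoromethyl group on that aromatic carbon would read in this assay when set against the methyl and fluoro compounds.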